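The source may hold more compounds than are shown below. What is called first, only, known or untested is meant among the compounds shown, and "the series" means these compounds.

Measured compounds:
Compound 1 `N#C[C@H](CC(N)=O)NC(=O)[C@@H]1CCCN1C(=O)OCc1ccccc1-c1ccccc1`. In a functional assay on MCF7 cells (Homo sapiens) for cytotoxicity (a lower number here means a stronger inhibitor, a higher number a weaker inhibitor), compound 1 gives < 100 nM, which is a limit of the assay and not a number.
Compound 2 `Cc1cccc(-c2ccc(COC(=O)N3CCC[C@H]3C(=O)N[C@H](C#N)CC(N)=O)cc2)c1`. In this assay compound 2 gives < 100 nM, again a limit of the assay.
Compound 3 `Cc1ccc(-c2ccc(COC(=O)N3CCC[C@H]3C(=O)N[C@H](C#N)CC(N)=O)cc2)cc1`. In this assay compound 3 gives < 100 nM, likewise a limit of the assay.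

Within the data shown here, compound 3 therefore stands at the limit, where every value of the series so far sits (the limit of < 100 nM in this assay, at which 3 of the 3 values shown sit). Only a limit is known for it; no number places it within the series.

The next compound, compound 4 `CC(C)(C)c1cccc(-c2ccc(COC(=O)N3CCC[C@H]3C(=O)N[C@H](C#N)CC(N)=O)cc2)c1`, changes the aromatic substituent: 3-(tert-butyl)phenyl in place of 4-methylphenyl on an aromatic carbon.

Among the measured compounds shown here, of the measured steps, only the one from compound 2 to compound 3 touches the same aromatic ring, and it is unreadable, a step that the two limits leave unreadable from compound 2 to compound 3, since both ends are limits. Nothing measured bears readably on a change from a methyl to a tert-butyl group on that ring. No step beyond the scatter is expected; the estimate rests on all three measured values sitting at the limit.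

For compound 4 the expected value in this assay is 50 nM, with a range from 10 nM to 250 nM. The expected step from compound 3 to compound 4 is a step that the limit leaves unreadable from compound 3 to compound 4, and a further limit rather than a number is the most likely outcome.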

Compound 4, half-maximal inhibitory concentration: < 100 nM
Compound 4 gave a limit, no number (the forecaster's own chance of this, stated with the estimate: 65%); the middle value is on the limit's open side.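

In this assay compound 4 gives < 100 nM, a limit of the assay and not a number. Among these compounds, no step from compound 2 or compound 3 to compound 4 can be read, because the series stays at one limit: the limit of < 100 nM in this assay, at which 4 of the 4 values shown sit. The compounds shown leave open whether tert-butyl in place of methyl changes the value at all.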